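The source may report more compounds than this note shows. Statements on the series, on what has been measured and on what is new or still open speak of the compounds shown alone.

Measured so far in a functional assay on MDA-MB-436 cells (Homo sapiens) for antiproliferative activity, read by MTT assay, with a stated time of 24 h; a higher number here means a weaker inhibitor, a lower number a stronger inhibitor:
- compound 1 `O=C(O)CC(NS(=O)(=O)c1ccccc1)c1ccccc1`: > 100000 nM
- compound 2 `O=C(O)CC(NS(=O)(=O)c1ccc(F)cc1)c1ccccc1`: > 100000 nM
- compound 3 `O=C(O)CC(NS(=O)(=O)c1ccccc1Br)c1ccccc1`: > 100000 nM

Each of these entries is a limit of the assay, not a number. Compound 3 therefore has no exact place in the series, and it shares its position with the other two compounds: the limit of > 100000 nM in this assay, at which 3 of the 3 values shown sit.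

Compound 4 `O=C(O)CC(NS(=O)(=O)c1ccccc1Br)c1ccc(Cl)cc1Cl` keeps the 2-bromophenyl group on the sulfonyl sulfur of compound 3. The change lies on a saturated chain carbon bound to a saturated chain carbon and a sulfonamide nitrogen, where 2,4-dichlorophenyl replaces phenyl: 2,4-dichlorophenyl in place of phenyl on a saturated chain carbon bound to a saturated chain carbon and a sulfonamide nitrogen.

Three measured steps could offer guidance: a step that the two limits leave unreadable from compound 1 to compound 2, a step that the two limits leave unreadable from compound 1 to compound 3 and a step that the two limits leave unreadable from compound 2 to compound 3. None has a readable size, and all three alter the group on the sulfonyl sulfur, not the phenyl that leaves here. They therefore give no measured size for this change. In this assay, only a modest move towards stronger inhibition is expected, and compound 4 may well remain at the same limit.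

The expected change is an at least 1.2-fold lower number from compound 3 to compound 4 (0.09 log units; that floor lies within the scatter).

For compound 4 the estimated value is 80000 nM, with an expected range from 20000 nM to 200000 nM.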

Compound 4, half-maximal inhibitory concentration: > 100000 nM
Compound 4: a limit, no number; the forecaster's own chance of this, stated with the estimate: 60%; middle value at least 1.2-fold (0.09 log units) away from the limit.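

Going by these compounds alone, compound 3 and compound 4 each give a limit of the assay and not a number, so no step between them can be read. The compounds shown leave open how strong any of them is in this assay, and whether changing the group on the sulfonyl sulfur or the 2,4-dichlorophenyl swap alters that at all: the limit of > 100000 nM in this assay, at which 4 of the 4 values shown sit.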